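Bromine in place of fluorine on the benzyl ether

The source may report more compounds than this note shows. Statements on the series, on what has been measured and on what is new or still open speak of the compounds shown alone.

Within the data shown here, compound 1 `COc1cc(OC)c(-c2coc3cc(OCc4ccccc4F)ccc3c2=O)cc1OC` is the only member of this set to give a number in a functional assay on HUVEC cells (Homo sapiens) for antiproliferative activity, read by MTT assay, with a stated time of 24 h; on this read-out higher numbers stand for weaker inhibition and lower numbers for stronger inhibition: there compound 1 gives 4300 nM. Compound 2 `COc1cc(OC)c(-c2coc3cc(OCc4ccc([N+](=O)[O-])cc4)ccc3c2=O)cc1OC` reaches only a limit in this assay, where compound 2 gives > 10000 nM. Compound 3 `COc1cc(OC)c(-c2coc3cc(OCc4ccc(C#N)cc4)ccc3c2=O)cc1OC` likewise returns a limit, with compound 3 giving > 10000 nM in this assay. The steps of an at least 2.3-fold higher number from compound 1 to compound 2 (0.36 log units; beyond the scatter) and an at least 2.3-fold higher number from compound 1 to compound 3 (0.36 log units; beyond the scatter) show higher numbers once the 2-fluorophenyl is replaced, while the step that the two limits leave unreadable from compound 2 to compound 3 cannot be sized, since (the limit of > 10000 nM in this assay, at which 2 of the 3 values shown sit). Compound 4 `COc1cc(OC)c(-c2coc3cc(OCc4ccccc4Br)ccc3c2=O)cc1OC` differs from compound 1 by bromo in place of fluoro on an aromatic carbon. Among the measured compounds shown here, no measured step touches this exchange alone, and the 2-fluorophenyl of compound 1 is kept in spirit. The step of a 1.1-fold lower number from compound 1 to compound 4 (0.03 log units; within the scatter) is therefore expected to stay within the scatter, and compound 4 is estimated at 4000 nM, between 1500 nM and 10000 nM.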

Compound 4, half-maximal inhibitory concentration: > 10000 nM
Compound 4: no number, only a limit; the forecaster's own chance of this, stated with the estimate: 25%; middle value at least 2.5-fold (0.39 log units) from the limit.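

Bromo in place of fluoro on the same aromatic carbon gives an at least 2.3-fold higher number from compound 1 to compound 4 (0.36 log units; beyond the scatter) in this assay and so shows that this position responds to the exchange of one halogen for another. The loss seen with the 4-nitrophenyl and 4-cyanophenyl groups is therefore not confined to those groups, and among the compounds shown only the 2-fluorobenzyl of compound 1 keeps a number. The steps joining compound 4 to compound 2 and compound 3 cannot be read: the limit of > 10000 nM in this assay, at which 3 of the 4 values shown sit.

Going by these compounds, whether 2-chlorobenzyl, 2-methylbenzyl or plain benzyl would give a number stays open. So does how far past its limit compound 4 lies.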